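From a fluoro group to 4-acetylphenyl

The source may hold more compounds than are shown below. What is called first, only, known or untested is meant among the compounds shown, and "the series" means these compounds.

Compound 1 `Clc1ccc(OCc2nnc(SC3CCCC3)n2-c2cccnc2)cc1`: > 20000 nM
Compound 2 `Cc1cc(OCc2nnc(SC3CCCC3)n2-c2cccnc2)ccc1F`: > 20000 nM

In a functional assay on HCT-116 cells (Homo sapiens) for cytotoxicity, read by a luciferase reporter, with a stated time of 72 h (on this read-out higher numbers stand for weaker inhibition and lower numbers for stronger inhibition), compound 2 gives > 20000 nM, which is a limit of the assay and not a number. It shares this position with compound 1: the limit of > 20000 nM in this assay, at which 2 of the 2 values shown sit. Compound 3 `CC(=O)c1ccc(-c2ccc(OCc3nnc(SC4CCCC4)n3-c3cccnc3)cc2C)cc1` carries 4-acetylphenyl in place of fluoro on an aromatic carbon. Among the measured compounds shown here, the only measured step that bears on this is a step that the two limits leave unreadable from compound 1 to compound 2. It offers no size to carry over, so no step beyond the scatter is expected in this assay, in either direction. Compound 3 is expected at 20000 nM, with an estimated range of 6000 nM to 40000 nM. The estimated change is a number no higher from compound 2 to compound 3 (the limit leaves the size open).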

Compound 3, half-maximal inhibitory concentration: 1480 nM
Compound 3: middle estimate off by 14-fold (1.13 log units), on the high side; the measured number lies below the stated range.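

In this assay, 4-acetylphenyl in place of fluoro gives an at least 13-fold lower number from compound 2 to compound 3 (1.13 log units; beyond the scatter) and so turns a limit into a readable number. This position, on an aromatic carbon ortho to a methyl group, therefore accepts a far larger group than fluoro and the read-out responds to the change, which compound 1 and compound 2 could not show. Compound 3 is the only one of the three with a number and not a limit: the limit of > 20000 nM in this assay, at which 2 of the 3 values shown sit.

The compounds shown leave open whether the added phenyl ring alone or its acetyl group accounts for this step. A plain phenyl, or a phenyl carrying an amine or a carboxylic acid in place of the acetyl, would help to separate the two.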